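A few compounds are considered here, and "the series" means these few. Any claim that something is new, unique, unknown or untested is made for them only; others in the source may bear on it.

Measured so far:
Compound 1 `O=c1c(SC(=S)N2CCCC2)coc2ccc(Cl)cc12` — 16300 nM
Compound 2 `O=c1c(SC(=S)N2CCCCC2)coc2ccccc12` — 9000 nM
Compound 3 `O=c1c(SC(=S)N2CCCCC2)coc2ccc(Cl)cc12` — 8300 nM

All three were tested in a functional assay on HeLa cells (Homo sapiens) for antiproliferative activity, read by MTT assay, with a stated time of 72 h; on this read-out lower numbers stand for stronger inhibition and higher numbers for weaker inhibition. Compound 2 stands second highest of the three numbers; its nearest neighbour is compound 3, which gave 8300 nM, and the step from it, a 1.1-fold lower number from compound 2 to compound 3 (0.04 log units; within the scatter), lies within the scatter. Compound 1 gave 16300 nM, and the step of a 2.0-fold lower number from compound 1 to compound 3 (0.29 log units; within the scatter) is likewise within the scatter.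

The unmeasured compound 4 `O=c1c(SC(=S)N2CCCC2)coc2ccccc12` differs from compound 2 by pyrrolidin-1-yl in place of piperidin-1-yl on a thiocarbonyl carbon. Among the compounds with values here, the only measured step that bears on this change is the one from compound 1 to compound 3, where the same two groups are exchanged in the other direction on the chloro-bearing core: a 2.0-fold lower number from compound 1 to compound 3 (0.29 log units; within the scatter). Running that exchange backwards on the core of compound 2, the expected step is a modest rise in the number, a 1.8-fold higher number from compound 2 to compound 4 (0.25 log units; within the scatter), which stays within the scatter. Compound 4 is therefore estimated at 16000 nM, with a range from 7000 nM to 40000 nM.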

Compound 4, half-maximal inhibitory concentration: 3800 nM
Compound 4: the middle estimate sits 4.2-fold (0.62 log units) above what was measured; the whole stated range lies above it.
By their numbers in this assay, from the lowest: compound 4; then compounds 3, 2 and 1 (each within the scatter of the next).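

In this assay, pyrrolidin-1-yl in place of piperidin-1-yl on a thiocarbonyl carbon now gives a step beyond the scatter on the core without chloro, a 2.4-fold lower number from compound 2 to compound 4 (0.37 log units; beyond the scatter), whereas the same exchange on the chloro-bearing core stayed within it: the same change on two cores in this assay, a 2.0-fold lower number (0.29 log units; within the scatter) from compound 1 to compound 3 and a 2.4-fold higher number (0.37 log units; beyond the scatter) from compound 4 to compound 2, 4.7-fold (0.67 log units) apart, beyond the scatter of two such steps. Hydrogen in place of chloro on an aromatic carbon also gives a step beyond the scatter with pyrrolidin-1-yl present, a 4.3-fold lower number from compound 1 to compound 4 (0.63 log units; beyond the scatter), although this change stayed within the scatter with piperidin-1-yl present: the same change on two cores in this assay, a 1.1-fold lower number (0.04 log units; within the scatter) from compound 2 to compound 3 and a 4.3-fold higher number (0.63 log units; beyond the scatter) from compound 4 to compound 1, 4.7-fold (0.67 log units) apart, beyond the scatter of two such steps. Across these four compounds, the two changes therefore do not act independently, and the size of each step depends on the other group.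

Going by these compounds, whether this dependence extends to other amines on the thiocarbonyl carbon, such as morpholin-4-yl or diethylamino, remains open. On these data alone, it is also open whether fluoro or methoxy in place of chloro would behave in the same way.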